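A few compounds are considered here, and "the series" means these few. Any claim that something is new, unique, unknown or untested is made for them only; others in the source may bear on it.

Within the data shown here, compound 1, `CCS(=O)(=O)Nc1cccc2c1CCCC2c1c[nH]cn1`, is the only compound with a numerical value in this set: in an assay on isolated protein for binding affinity to Alpha-1D adrenergic receptor (Rattus norvegicus), read by radioligand binding (on this read-out higher numbers stand for weaker inhibition and lower numbers for stronger inhibition), compound 1 gives 1070 nM. Compound 2, `CCS(=O)(=O)Nc1cccc2c1CCCC2(O)c1c[nH]cn1`, reaches only a limit: in this assay compound 2 gives < 10000 nM, a limit of the assay and not a number. So a step that the limit leaves unreadable from compound 1 to compound 2 cannot be read, as the limit of < 10000 nM in this assay, at which 1 of the 2 values shown sits, shows. Compound 3, `CCS(=O)(=O)Nc1cc(Cl)cc2c1CCCC2c1c[nH]cn1`, differs from compound 1 by chloro in place of hydrogen on an aromatic carbon. Among the measured compounds shown here, no measured step involves such a change, so nothing points to a direction. Compound 3 is therefore expected to show a step of a 1.1-fold lower number from compound 1 to compound 3 (0.03 log units; within the scatter), within the scatter. Compound 3 is estimated at 1000 nM, between 400 nM and 2500 nM.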

Compound 3, inhibition constant: 363 nM
Estimate against measurement, compound 3: 2.8-fold (0.44 log units) above, outside the stated range (below it).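

In this assay, among these compounds, chloro in place of hydrogen on the aromatic carbon meta to the (ethylsulfonyl)amino group gives a 2.9-fold lower number from compound 1 to compound 3 (0.47 log units; beyond the scatter), the first step in this set that can be read. This shows that the position responds to a change, and that a single chlorine atom moves the number towards stronger inhibition. The step to compound 2 cannot be read, since its value is a limit and not a number: the limit of < 10000 nM in this assay, at which 1 of the 3 values shown sits.

The compounds shown leave open whether fluoro, bromo, methyl or methoxy at this position would do the same. Among the compounds shown here, they also leave open whether chloro is the only group that gives such a step.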